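The source may report more compounds than this note shows. Statements on the series, on what has been measured and on what is new or still open speak of the compounds shown alone.

In a functional assay on HepG2 cells (Homo sapiens) for inhibition, read by MTT assay, with a stated time of 24 h (on this read-out lower numbers stand for stronger inhibition and higher numbers for weaker inhibition), compound 1 `COc1ccc(/C=N/NC(=O)CNC(=O)c2ccc(F)cc2)c(OCc2ccccc2Cl)c1` gives 15700 nM and compound 2 `O=C(COc1ccc(Cl)cc1)NCc1ccc(CNC(=O)COc2ccc(Cl)cc2)cc1` gives 26400 nM, two values within the scatter of each other. Compound 3 `CCN(CC)c1ccc(/C=N/NC(=O)CNC(=O)c2ccc(F)cc2)c(OCc2ccccc2Cl)c1` keeps the rest of compound 1 but carries diethylamino in place of methoxy on an aromatic carbon, para to a large group and meta to a (2-chlorobenzyl)oxy group (diethylamino in place of methoxy on an aromatic carbon). Going by the values given here, no measured pair shows what such a change does in this assay, so only a slight lean toward lower numbers, not beyond the scatter, is expected, an estimated 1.3-fold lower number from compound 1 to compound 3 (0.12 log units; within the scatter). For compound 3 the estimated value is 12000 nM, with an expected range of 5000 nM to 30000 nM.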

Compound 3, half-maximal inhibitory concentration: > 50000 nM
Compound 3 ended at the assay's limit; the forecaster's own chance of this, stated with the estimate: 10%; middle value at least 4.1-fold (0.61 log units) from the limit.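

In this assay, going by these compounds alone, diethylamino in place of methoxy on this aromatic carbon, para to a large group, gives an at least 3.1-fold higher number from compound 1 to compound 3 (0.50 log units; beyond the scatter) and so provides the first measured step at this position, one that lies beyond the scatter. Compound 3 stands at > 50000 nM, which is a limit of the assay and not a number, and the step therefore has only a lower bound: the limit of > 50000 nM in this assay, at which 1 of the 3 values shown sits.

The compounds shown leave open whether a smaller group at this position, such as dimethylamino, a free amine or ethoxy, would stay close to compound 1. They also leave open how far the step from methoxy to diethylamino actually reaches.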